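Swapping the Aryl Acid Along a Flexible Linker

This account rests on a few compounds, and the source may have more. Where it says the series, first, only, none or still open, it means among the compounds named here.

Going by the values given here, compound 2 `Cc1ccc(C(=O)O)cc1OCCCCOc1ccc(C(=O)CC(C)C)c(O)c1C` gives 454 nM in an assay on HEK293 cells for positive allosteric modulation of metabotropic glutamate receptor 2 (Rattus norvegicus), read by thallium flux, with a stated time of 2.5 min (on this read-out higher numbers stand for an effect only at larger amounts of compound and lower numbers for an effect already at smaller amounts), the higher of the two numbers measured so far. Compound 1 `Cc1c(OCCCCOc2ccc(F)c(C(=O)O)c2)ccc(C(=O)CC(C)(C)C)c1O` gives 208 nM in this assay, a gap that lies beyond the usual scatter. Compound 3 `Cc1c(OCCCCOc2ccc(F)c(C(=O)O)c2)ccc(C(=O)CC(C)C)c1O` differs from compound 2 by 3-carboxy-4-fluorophenyl in place of 5-carboxy-2-methylphenyl on an oxygen on a saturated carbon. Compound 1 carries this same 3-carboxy-4-fluorophenyl group and gives 208 nM, so a move toward an effect at smaller amounts is expected. In this assay the expected step is a 1.6-fold lower number from compound 2 to compound 3 (0.21 log units; within the scatter). For compound 3 the estimate is 280 nM, ranging from 120 nM to 650 nM.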

Compound 3, half-maximal effective concentration: 153 nM
Beside the measured number, compound 3's estimate is 1.8-fold (0.26 log units) above it; measured number inside the range.
By their numbers in this assay, from the lowest: compounds 3 and 1 (each within the scatter of the next); then compound 2.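

In this assay, going by these compounds alone, 3-carboxy-4-fluorophenyl in place of 5-carboxy-2-methylphenyl gives a 3.0-fold lower number from compound 2 to compound 3 (0.47 log units; beyond the scatter); compounds 1 and 2 differed in more than one place, so only this pair isolates the effect of the aryl acid. Hydrogen in place of methyl on the saturated chain carbon gives a 1.4-fold lower number from compound 1 to compound 3 (0.13 log units; within the scatter), so that edit does not separate these two compounds. Nothing measured here explains the effect of the aryl swap. Still open, going by these compounds, is whether the fluorine, the lost methyl or the moved carboxylic acid accounts for the step. On these data alone, how an amide in place of that acid, or a longer chain between the two oxygens, would read also remains unknown.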